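This account rests on a few compounds, and the source may have more. Where it says the series, first, only, none or still open, it means among the compounds named here.

Working notes on the amidine series. Of the compounds shown here, two have numbers so far. Compound 1 `CC1CCC(C)N1CCCCCN1C(=O)C(c2cccc(C(=N)N)c2)Oc2ccccc21` gives 760 nM in an assay on isolated protein for inhibition of serine protease 1 (Homo sapiens); a lower number here means a stronger inhibitor, a higher number a weaker inhibitor. Compound 2 `CC1CCCC(C)N1CCCCCCN1C(=O)C(c2cccc(C(=N)N)c2)Oc2ccccc21` gives 2100 nM in this assay; of the two numbers this is the highest, with compound 1 as its nearest neighbour. Among the compounds with values here, the one measured step, a 2.8-fold higher number from compound 1 to compound 2 (0.44 log units; beyond the scatter), concerns (2,6-dimethylpiperidin-1-yl)methyl in place of 2,5-dimethylpyrrolidin-1-yl on a saturated chain carbon, five bonds along the chain from an amide-type nitrogen in a ring.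

Compound 3 `N=C(N)c1cccc(C2Oc3ccccc3N(CCCCCN3CCCCC3)C2=O)c1` is not yet measured. It differs from compound 2 by piperidin-1-yl in place of (2,6-dimethylpiperidin-1-yl)methyl on a saturated chain carbon, five bonds along the chain from an amide-type nitrogen in a ring. This change goes back toward compound 1 in two respects: the chain is again as in compound 1, and the ring on the chain carbon carries no methyl groups. Within the data shown here, the step from compound 1 to compound 2 is the only measured guide, and it suggests the number should return toward that of compound 1, though it does not show how an unsubstituted ring compares with a dimethyl-substituted one. The expected step is a 3.0-fold lower number from compound 2 to compound 3 (0.48 log units; beyond the scatter), a lower number in this assay. Compound 3 is therefore expected to give about 700 nM, with a range from 250 nM to 2000 nM.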

Compound 3, half-maximal inhibitory concentration: 990 nM
Compound 3: middle estimate off by 1.4-fold (0.15 log units), on the low side, and the stated range covers the measured number.
By their numbers in this assay, from the lowest: compounds 1 and 3 (each within the scatter of the next); then compound 2.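

In this assay, piperidin-1-yl in place of (2,6-dimethylpiperidin-1-yl)methyl gives a 2.1-fold lower number from compound 2 to compound 3 (0.33 log units; beyond the scatter) and so leaves compound 2 apart from compound 3 by more than the scatter. Piperidin-1-yl in place of 2,5-dimethylpyrrolidin-1-yl gives a 1.3-fold higher number from compound 1 to compound 3 (0.11 log units; within the scatter) and so does not separate these two groups on this saturated chain carbon, which shows that a ring without methyl groups can stand here with no change that can be read. No measurement is at hand that explains these numbers.

The compounds shown do not separate the effect of the extra chain carbon from that of the two methyl groups, since 2,6-dimethylpiperidin-1-yl on the chain of compound 3, or piperidin-1-yl on the chain of compound 2, would be needed to read each change alone. Also open, from the compounds shown here alone, is how a morpholin-4-yl or dimethylamino group on the same chain carbon, or a shorter chain carrying piperidin-1-yl, would compare with compound 3.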